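Ortho substitution on the aryl ring of the oxo-acid core

This account rests on a few compounds, and the source may have more. Where it says the series, first, only, none or still open, it means among the compounds named here.

Measured compounds:
Compound 1 `O=C(O)c1cnc(-c2ccccc2)[nH]c1=O` gives 50 mg/kg.
Compound 2 `Nc1ccccc1-c1ncc(C(=O)O)c(=O)[nH]1` gives 50 mg/kg.

Both were run in a functional assay on the whole organism (strain Sprague-Dawley) for inhibition, with Rattus norvegicus as the target, with a stated time of 10 min; a higher number here means that more compound is needed for the effect, a lower number that less compound is needed. Compound 1 stands level with compound 2 at the digits recorded; the step of no change at the digits printed from compound 1 to compound 2 (within the scatter), amino in place of hydrogen on an aromatic carbon, lies within the scatter. Nothing else has been measured, so compound 1 has no neighbour that moves the number.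

Compound 3 `CCCCOc1ccccc1-c1ncc(C(=O)O)c(=O)[nH]1` is the next entry and has not yet been run in this assay. It differs from compound 1 by butoxy in place of hydrogen on an aromatic carbon. The change sits on an aromatic carbon of a six-membered aromatic ring of carbon only, the same kind of position as the amino group of compound 2. Going by the values given here, the only step that bears on it is no change at the digits printed from compound 1 to compound 2 (within the scatter), which was flat. Butoxy is a larger group than amino and brings no donor, so the amino step is only a partial guide; still, nothing in the series points to a direction. No step beyond the scatter is therefore expected in this assay. The expected step is no change at the digits printed from compound 1 to compound 3 (within the scatter). Compound 3 is estimated at 50 mg/kg, with a range from 20 mg/kg to 120 mg/kg.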

Compound 3, dose for 50% inhibition: 0.5 mg/kg
Compound 3: the middle estimate sits 100-fold (2.00 log units) above what was measured; measured number outside the range, below it.
By their numbers in this assay, from the lowest: compound 3; then compounds 1 and 2 (each within the scatter of the next).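

In this assay the aromatic carbon ortho to a large group proves far from indifferent to substitution: butoxy in place of hydrogen gives a 100-fold lower number from compound 1 to compound 3 (2.00 log units; beyond the scatter) on the shared core, whereas amino in place of hydrogen gave only no change at the digits printed from compound 1 to compound 2 (within the scatter) at this kind of position. The exchange of one group for the other gives a 100-fold lower number from compound 2 to compound 3 (2.00 log units; beyond the scatter) as well, so the outcome at this carbon depends on which group enters, and the flat amino step did not describe the position as a whole. The data here hold nothing that accounts for the gain with butoxy, and no measurement bears on its cause.

The compounds shown leave open how much of the butoxy group the result needs: methoxy, a longer chain such as hexyloxy, or a plain butyl chain without the oxygen would separate the length of the chain from the ether oxygen. They also leave open whether butoxy has the same effect on another carbon of the aromatic ring, and whether the effect survives when the carboxylic acid of the core gives way to a primary amide.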